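This account rests on a few compounds, and the source may have more. Where it says the series, first, only, none or still open, it means among the compounds named here.

Measured compounds:

Compound 1 `C/C(=C\c1cc(-c2ccc(C)cc2)co1)C(N)=O` gives in a functional assay on BGC-823 cells (Homo sapiens) for cytotoxicity, read by CCK-8 assay, with a stated time of 24 h (on this read-out higher numbers stand for weaker inhibition and lower numbers for stronger inhibition), only the limit > 50000 nM and no number.
Compound 2 `C/C(=C\c1cc(-c2ccc(F)cc2)co1)C(N)=O` gives in this assay only the limit > 50000 nM and no number.
Compound 3 `C/C(=C\c1cc(-c2ccc(C)nc2)co1)C(N)=O` gives in this assay only the limit > 50000 nM and no number.

All three values sit at the limit of > 50000 nM in this assay, at which 3 of the 3 values shown sit. Between compound 1 and compound 2 the change is fluoro in place of methyl on an aromatic carbon, and the step that the two limits leave unreadable from compound 1 to compound 2 is one that the two limits leave unreadable. The difference between the core of compound 1 and the core of compound 3 is not broken down here.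

Compound 4 `C/C(=C\c1cc(-c2ccc(F)nc2)co1)C(N)=O` has not yet been measured in this assay. It differs from compound 3 by fluoro in place of methyl on an aromatic carbon. Within the data shown here, this is the same kind of change as the one from compound 1 to compound 2, but the place is not the same: there it sat on a six-membered aromatic ring of carbon only, here on a six-membered aromatic ring with 1 nitrogen, next to the ring nitrogen.

Because the three measured values all rest at the limit of > 50000 nM in this assay, at which 3 of the 3 values shown sit, compound 4 is expected to give 60000 nM in this assay, most likely reported again as a limit rather than a number. The step that the limit leaves unreadable from compound 3 to compound 4 is thus estimated to be small.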

Compound 4, half-maximal inhibitory concentration: > 50000 nM
Compound 4 gave a limit, no number; the forecaster's own chance of this, stated with the estimate: 85%; the middle value does not contradict the limit.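

In this assay compound 4 gives only the limit > 50000 nM and no number. Among these compounds, compound 3 likewise gave only a limit, so no step between compound 3 and compound 4 can be read. The compounds shown leave open how strongly any of them acts on these cells and whether fluoro in place of methyl changes that, as every value rests at one limit: the limit of > 50000 nM in this assay, at which 4 of the 4 values shown sit.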